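The source may hold more compounds than are shown below. What is called first, only, known or untested is meant among the compounds shown, and "the series" means these compounds.

Compound 1 `O=S(=O)(NCCCNCc1ccc(Cl)c(C(F)(F)F)c1)c1cc(C(F)(F)F)cc(C(F)(F)F)c1` belongs to a small set of three analogues sharing one core, in which the chain carries an aromatic group on a saturated chain carbon bound to an amine nitrogen. In a functional assay on Capan-2 cells (Homo sapiens) for inhibition, read by MTT assay, with a stated time of 72 h (on this read-out lower numbers stand for stronger inhibition of growth and higher numbers for weaker inhibition of growth), compound 1 gives 9100 nM, the highest of the three numbers, so it is the weakest grower-inhibitor among the measured compounds. Compound 2 `COc1ccc(CNCCCNS(=O)(=O)c2cc(C(F)(F)F)cc(C(F)(F)F)c2)cc1` gives 2400 nM and compound 3 `O=S(=O)(NCCCNCc1ccc(Cl)cc1)c1cc(C(F)(F)F)cc(C(F)(F)F)c1` gives 2700 nM; the step of a 1.1-fold higher number from compound 2 to compound 3 (0.05 log units; within the scatter) shows these two within the scatter of each other.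

Compound 4 `COc1ccccc1CNCCCNS(=O)(=O)c1cc(C(F)(F)F)cc(C(F)(F)F)c1` has not yet been measured. Compared with compound 1, it carries 2-methoxyphenyl in place of 4-chloro-3-(trifluoromethyl)phenyl on a saturated chain carbon bound to an amine nitrogen. Within the data shown here, two measured steps bear on this change: a 3.8-fold lower number from compound 1 to compound 2 (0.58 log units; beyond the scatter), where a methoxyphenyl group likewise replaced the same departing group, and a 3.4-fold lower number from compound 1 to compound 3 (0.53 log units; beyond the scatter), where only the trifluoromethyl was removed. Both gave a modest move toward lower numbers, beyond the scatter. A step of about the same size and direction is therefore expected for compound 4, namely a 3.3-fold lower number from compound 1 to compound 4 (0.51 log units; beyond the scatter). Compound 4 is expected to give 2800 nM in this assay, with a likely range from 1100 nM to 7000 nM.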

Compound 4, concentration for 50% growth inhibition: 6000 nM
Estimate against measurement, compound 4: 2.1-fold (0.33 log units) below; low and high end bracket the measured number.
By their numbers in this assay, from the lowest: compounds 2 and 3 (each within the scatter of the next); then compounds 4 and 1 (each within the scatter of the next).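

In this assay, replacing 4-chloro-3-(trifluoromethyl)phenyl at this place does not always move the number beyond the scatter: the change to 2-methoxyphenyl gives a 1.5-fold lower number from compound 1 to compound 4 (0.18 log units; within the scatter) and so leaves the two compounds indistinguishable. Nor are the two methoxyphenyl groups interchangeable here, since 2-methoxyphenyl in place of 4-methoxyphenyl gives a 2.5-fold higher number from compound 2 to compound 4 (0.40 log units; beyond the scatter) and goes beyond the scatter. The step from 4-chlorophenyl to 2-methoxyphenyl gives a 2.2-fold higher number from compound 3 to compound 4 (0.35 log units; beyond the scatter) and is also modest, so compound 4 stands apart from compounds 2 and 3 while remaining level with compound 1.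

No measurement shown here explains why the two methoxyphenyl groups give different numbers. Also open, from the compounds shown here alone, is how an amine or a carboxylic acid on the aromatic group, or a longer chain, would affect growth inhibition.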